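The source may report more compounds than this note shows. Statements on the series, on what has been measured and on what is new or still open speak of the compounds shown alone.

Among the compounds with values here, in a functional assay on B16 cells (Mus musculus) for cytotoxicity, read by MTT assay, with a stated time of 48 h (a lower number here means a stronger inhibitor, a higher number a weaker inhibitor), compound 1 `C#CCNC(=O)c1cn(Cc2ccccc2)nn1` gives 65000 nM, the only exact number in this small set. Compound 2 `C#CCNC(=O)c1cn(CCOC(C)=O)nn1` shows only a limit of the assay, > 100000 nM. Compound 3 `O=C(Nc1ccc(-c2cn(Cc3ccccc3)nn2)cc1)c1cn(Cc2ccccc2)nn1`, which carries an aromatic ring on its amide-type nitrogen, also shows only a limit, > 100000 nM. The picture so far is therefore shaped by the limit of > 100000 nM in this assay, at which 2 of the 3 values shown sit.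

Compound 4 `O=C(Nc1ccccc1)c1cn(Cc2ccccc2)nn1` keeps the core of compound 1 and changes one group: phenyl in place of propargyl on an amide-type nitrogen. In short, phenyl replaces propargyl on an amide-type nitrogen.

Within the data shown here, only one measured step is available, an at least 1.5-fold higher number from compound 1 to compound 2 (0.18 log units; that floor lies within the scatter). That change sits elsewhere, on a saturated chain carbon bound to an aromatic nitrogen, so it bears on this new change only loosely. No step beyond the scatter is therefore expected in this assay, although the nearby limit leaves little room for a clear reading. The estimated shift is small, a 1.1-fold higher number from compound 1 to compound 4 (0.03 log units; within the scatter). For compound 4 the expected value is 70000 nM, within an estimated range of 30000 nM to 120000 nM.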

Compound 4, half-maximal inhibitory concentration: 93000 nM
Compound 4: middle estimate off by 1.3-fold (0.12 log units), on the low side, and the stated range covers the measured number.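

In this assay, replacing propargyl with phenyl on the amide-type nitrogen gives a 1.4-fold higher number from compound 1 to compound 4 (0.16 log units; within the scatter). Within the data shown here, this is the first exact reading for a change at this position, and compound 4 has no triple bond outside aromatic rings yet still gives a number rather than a limit, so the triple bond of propargyl is not needed for a measurable value here. A six-membered aromatic ring can also take the place of the three-carbon propargyl group on this nitrogen without a step beyond the scatter.

Even so, the exact values stay close to the top of the measurable range, so there is little room to read small differences: the limit of > 100000 nM in this assay, at which 2 of the 4 values shown sit. Whether a longer chain or an amine on this nitrogen could bring the number clearly down remains open.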